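Sulfonamide aryl variation in the methoxyphenylpiperazine series

A few compounds are considered here, and "the series" means these few. Any claim that something is new, unique, unknown or untested is made for them only; others in the source may bear on it.

Measured so far:
compound 1 `COc1ccc(S(=O)(=O)Nc2cccc(Br)c2)cc1N1CCNCC1`: 1.26 nM
compound 2 `COc1ccc(S(=O)(=O)Nc2cccc(I)c2)cc1N1CCNCC1`: 0.501 nM
compound 3 `COc1ccc(Cl)cc1NS(=O)(=O)c1ccc(OC)c(N2CCNCC2)c1`: 1.26 nM

In an assay on isolated protein for binding affinity to 5-hydroxytryptamine receptor 6 (Homo sapiens) (a lower number here means a stronger inhibitor, a higher number a weaker inhibitor), compound 1 gives 1.26 nM, level with compound 3 at the digits shown, and the two together stand as the highest of the three numbers. Among the compounds with values here, the only step beyond the scatter is a 2.5-fold lower number from compound 1 to compound 2 (0.40 log units; beyond the scatter), an iodo in place of bromo on an aromatic carbon; the aryl swap no change at the digits printed from compound 1 to compound 3 (within the scatter) stays within the scatter, while a 2.5-fold higher number from compound 2 to compound 3 (0.40 log units; beyond the scatter) mirrors the halogen step.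

Compound 4 `COc1ccc(S(=O)(=O)Nc2ccc(C)cc2Br)cc1N1CCNCC1` has not yet been measured. Relative to compound 1 it carries 2-bromo-4-methylphenyl in place of 3-bromophenyl on a sulfonamide nitrogen. Both measured aryl swaps on the sulfonamide nitrogen bear on this: one moved the number not at all, the other modestly. The change here keeps bromine and adds a methyl, so the expected shift in this assay is small, probably within the scatter, with a slight lean toward a higher number, as a 1.6-fold higher number from compound 1 to compound 4 (0.20 log units; within the scatter).

Compound 4 is thus estimated at 2 nM, within 0.6 nM to 6.3 nM.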

Compound 4, inhibition constant: 7.94 nM
Estimate against measurement, compound 4: 4.0-fold (0.60 log units) below; the whole stated range lies below it.
By their numbers in this assay, from the lowest: compound 2; then compounds 1 and 3 (each within the scatter of the next); then compound 4.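

In this assay, the aryl group on the sulfonamide nitrogen proves less forgiving than the swap between compound 1 and compound 3 suggested: 2-bromo-4-methylphenyl in place of 3-bromophenyl gives a clear rise (a 6.3-fold higher number from compound 1 to compound 4 (0.80 log units; beyond the scatter)), even though bromine is kept. Within the data shown here, the same group also stands apart from the other two aryl groups (a 6.3-fold higher number from compound 3 to compound 4 (0.80 log units; beyond the scatter); a 16-fold higher number from compound 2 to compound 4 (1.20 log units; beyond the scatter)), the last being the only large step in the set and leaving compound 4 the weakest of the four. Nothing available bears on why this swap raises the number.

Still open, as far as these compounds go, is whether the rise follows the changed bromine position or the added methyl, as the two change together in compound 4. Also open, from the compounds shown here alone, is how an aryl group carrying an amine or a carboxylic acid would read in this assay.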